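This account rests on a few compounds, and the source may have more. Where it says the series, first, only, none or still open, it means among the compounds named here.

Measured so far:
compound 1 `C/C(=N\NC(=O)c1ccccc1O)c1c(C(=O)O)noc1C` — 52%
compound 2 `C/C(=N\NC(=O)c1cc(C(F)(F)F)cc(C(F)(F)F)c1)c1c(C(=O)O)noc1C` — 90%

In an assay on SNB-19 cells for inhibition of cystine/glutamate transporter (Homo sapiens), read by scintillation counting, with a stated time of 5 min, tested at 500 uM (a higher number here means more inhibition at the concentration tested (going by the name of the read-out), a lower number less inhibition), compound 1 stands lowest of the two numbers, and the nearest, compound 2, gives 90%, a gap beyond the usual scatter. Compound 3 `C/C(=N\NC(=O)c1ccccc1)c1c(C(=O)O)noc1C` has not yet been measured in this assay. It differs from compound 1 by one change, (hydrogen in place of hydroxy on an aromatic carbon), sitting on an aromatic carbon of a six-membered aromatic ring of carbon only. Going by the values given here, no measured pair shows this change, so its size can only be guessed. For compound 3 the step of a number 3 percentage points higher from compound 1 to compound 3 (within the scatter) is expected to stay within the scatter, with an estimate of 55% and a range from 25% to 85%.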

Compound 3, a percentage reported as inhibition, at one concentration (the size of the read-out at that concentration, not a potency): 83%
For compound 3 the middle estimate is 28 percentage points below the measured one, within the range that was stated.
By their numbers in this assay, from the lowest: compound 1; then compounds 3 and 2 (each within the scatter of the next).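

In this assay, going from 2-hydroxyphenyl to phenyl gives a number 31 percentage points higher from compound 1 to compound 3 (beyond the scatter). This aromatic carbon, ortho to a large group, therefore needs no hydroxy for inhibition at the concentration tested, and the hydroxy goes with a clearly lower number. The data offer no explanation for the size of this step.

Open, as far as these compounds go, is whether a methoxy group or an amine on this same carbon would also go with a lower number. Also open, from the compounds shown here alone, is whether a hydroxy elsewhere on the ring would do the same.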